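The source may hold more compounds than are shown below. What is called first, only, known or untested is meant among the compounds shown, and "the series" means these compounds.

Measured in an ADME assay on MDCK cells (Canis lupus familiaris) for cytotoxicity; a higher number here means that more compound is tolerated, a lower number that less compound is tolerated:
compound 1 `O=[N+]([O-])C1=CNc2nc(-c3ccco3)nn2C1c1ccc(O)c(O)c1`: > 1200000 nM (a limit of the assay, not a number)
compound 2 `O=[N+]([O-])C1=CNc2nc(-c3ccco3)nn2C1c1ccc(O)cc1O`: 119000 nM
compound 3 `O=[N+]([O-])C1=CNc2nc(-c3ccco3)nn2C1c1ccc(O)c(O)c1O`: 317000 nM

Compound 2 holds the lower of the two actual numbers, and the nearest one is reached by a 2.7-fold higher number from compound 2 to compound 3 (0.43 log units; beyond the scatter). The remaining entry is only a limit.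

The next structure, compound 4 `O=[N+]([O-])C1=CNc2nc(C(F)(F)F)nn2C1c1ccc(O)cc1O`, keeps the 2,4-dihydroxyphenyl of compound 2 and carries trifluoromethyl in place of furan-2-yl on an aromatic carbon. For the measured compounds named here, no measured step touches this place. The other two measured steps, an at least 10-fold lower number from compound 1 to compound 2 (1.00 log units; beyond the scatter) and an at least 3.7-fold lower number from compound 1 to compound 3 (0.57 log units; beyond the scatter), also change only the hydroxy pattern. Together they give a rough idea of how far one change can move this assay in this series, but no direction for the present swap. A slight upward lean is expected because compound 2 at 119000 nM already sits at the low end of the values seen so far. The expected change is small, and the estimate is a 1.7-fold higher number from compound 2 to compound 4 (0.23 log units; within the scatter). Compound 4 is estimated at 200000 nM, with an expected range of 60000 nM to 700000 nM.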

Compound 4, half-maximal cytotoxic concentration: 258000 nM
Compound 4: the middle estimate sits 1.3-fold (0.11 log units) below what was measured; low and high end bracket the measured number.
By their numbers in this assay, from the lowest: compound 2; then compounds 4 and 3 (each within the scatter of the next). At a limit, above all of these: compound 1.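

Notes on the aromatic carbon of the five-membered ring with 3 nitrogen: in this assay, trifluoromethyl in place of furan-2-yl gives a 2.2-fold higher number from compound 2 to compound 4 (0.34 log units; beyond the scatter), so this position also moves the read-out, and the direction of this one swap is towards more compound tolerated. The earlier steps shown here changed only the hydroxy pattern, whereas this step shows that the furan-2-yl ring can be replaced at this carbon by a group with no ring, with a modest change on the 2,4-dihydroxyphenyl background. Compound 1 remains a limit of the assay, not a number, and the only such entry among the values shown: the limit of > 1200000 nM in this assay, at which 1 of the 4 values shown sits.

With one swap at this carbon, the compounds shown do not separate the loss of the ring from the loss of the ring oxygen, nor do they show whether the step carries over to the 3,4-dihydroxyphenyl or the trihydroxyphenyl background. From the compounds shown here alone, how this assay responds to an amine, a carboxylic acid, a phenyl ring or a longer alkyl chain at this carbon also remains open.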